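The source may hold more compounds than are shown below. What is called first, only, known or untested is meant among the compounds shown, and "the series" means these compounds.

Compound 2 `CCc1ccc(C(=O)NN(C(=O)c2ccccc2Cl)C(C)(C)C)cc1` stands lowest of the three numbers measured in an assay on cells for agonist activity at ecdysone receptor (Bombyx mori), read by a luciferase reporter, with a stated time of 24 h; a higher number here means that more compound is needed for the effect, a lower number that less compound is needed: compound 2 gives 5.75 nM. Compound 1 `CC(C)(C)N(NC(=O)c1ccc(Br)cc1)C(=O)c1ccccc1Cl` is nearest, giving 33.9 nM, and compound 3 `Cc1ccc(C(=O)NN(C(=O)c2ccccc2Cl)C(C)(C)C)c(C)c1` lies furthest, giving 162 nM. The measured steps, a 5.9-fold lower number from compound 1 to compound 2 (0.77 log units; beyond the scatter), a 4.8-fold higher number from compound 1 to compound 3 (0.68 log units; beyond the scatter) and a 28-fold higher number from compound 2 to compound 3 (1.45 log units; beyond the scatter), all concern the substituent on the other benzoyl group, and two of them were modest while the last was large.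

Compound 4 `CCCCCCC(=O)N(NC(=O)c1ccc(CC)cc1)C(C)(C)C` differs from compound 2 in a different place: hexyl in place of 2-chlorophenyl on a carbonyl carbon. Going by the values given here, none of the measured steps touches this carbonyl carbon, so there is no step that bears directly on the change; the expectation can rest only on the general observation that every change of an aryl group so far moved the number beyond the scatter. The change from an aromatic ring to an open chain is larger than any of those, so a larger step toward a higher number is expected, with wide uncertainty. The step from compound 2 to compound 4 is thus expected to be a 26-fold higher number from compound 2 to compound 4 (1.42 log units; beyond the scatter). For compound 4 the value in this assay is estimated at 150 nM, within a range from 20 nM to 1500 nM.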

Compound 4, half-maximal effective concentration: 11700 nM
The estimate for compound 4 lay 78-fold (1.89 log units) below the measured number; the whole stated range lies below it.
By their numbers in this assay, from the lowest: compound 2; then compound 1; then compound 3; then compound 4.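

In this assay, the carbonyl carbon bonded to the amide-type nitrogen proves far more sensitive than the earlier changes suggested: hexyl in place of 2-chlorophenyl gives a 2000-fold higher number from compound 2 to compound 4 (3.31 log units; beyond the scatter), well beyond the largest earlier step, a 28-fold higher number from compound 2 to compound 3 (1.45 log units; beyond the scatter). Both groups carry six carbons and neither has a hydrogen-bond donor or acceptor, so matching these counts does not keep the number low; the change instead removes the aromatic ring and the chlorine. Nothing shown here accounts for the size of this step.

The compounds shown leave open whether the ring or the chlorine matters more, since phenyl or cyclohexyl on this carbonyl carbon would help separate the two. They also leave open whether a shorter chain such as propyl or a longer chain such as octyl would behave differently from hexyl.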